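Swapping chloro for dimethylamino on a fused bicyclic core

The source may hold more compounds than are shown below. What is called first, only, known or untested is meant among the compounds shown, and "the series" means these compounds.

Measured compounds:
compound 1 `Nc1nc(Cl)c(-c2nc3ccccc3o2)c(N[C@@H]2C[C@H](CO)[C@@H](O)[C@H]2O)n1`, 12000 nM
compound 2 `Nc1nc(Cl)c(-c2nc3ccc(Cl)cc3s2)c(N[C@@H]2C[C@H](CO)[C@@H](O)[C@H]2O)n1`, 16000 nM

Of the compounds shown here, two sharing the same amino-chloropyrimidine and cyclopentane-triol core have been tested in an ADME assay on cells (Homo sapiens) for cytotoxicity, read by polymerase chain reaction, with a stated time of 3 days; a higher number here means that more compound is tolerated, a lower number that less compound is tolerated. Compound 1 `Nc1nc(Cl)c(-c2nc3ccccc3o2)c(N[C@@H]2C[C@H](CO)[C@@H](O)[C@H]2O)n1` gives 12000 nM. Compound 2 `Nc1nc(Cl)c(-c2nc3ccc(Cl)cc3s2)c(N[C@@H]2C[C@H](CO)[C@@H](O)[C@H]2O)n1` gives 16000 nM, the higher of the two numbers, with compound 1 the nearest neighbour; the gap between them lies within the usual scatter, so the two cannot be ranked against each other on this evidence.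

Compound 3 `CN(C)c1ccc2nc(-c3c(Cl)nc(N)nc3N[C@@H]3C[C@H](CO)[C@@H](O)[C@H]3O)sc2c1` has not yet been tested. It differs from compound 2 in a single place: dimethylamino in place of chloro on an aromatic carbon. Going by the values given here, there is no measured pair in this set that isolates such a change, so the effect of the swap on this assay is unknown from the data; the only guide is that the two measured compounds, which differ in their fused ring systems, sit within the scatter of each other.

The step is therefore expected to be small, a 1.1-fold lower number from compound 2 to compound 3 (0.06 log units; within the scatter), with no direction beyond the scatter implied. Compound 3 is estimated at 14000 nM, within a range of 5000 nM to 40000 nM.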

Compound 3, half-maximal cytotoxic concentration: > 25000 nM
Compound 3 was reported as a limit; the forecaster's own chance of this, stated with the estimate: 25%; middle value at least 1.7-fold (0.25 log units) away from the limit.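

Going by these compounds alone, the pair of compound 2 and compound 3 is the first in this assay to isolate a single change, dimethylamino in place of chloro on an aromatic carbon, meta to a fused ring and para to a fused ring, whereas compound 1 and compound 2 differ in their fused ring systems. The swap brings no fall in the number at this position, with an at least 1.5-fold higher number from compound 2 to compound 3 (0.19 log units; that floor lies within the scatter), so the data give no sign that the larger group makes the compound less tolerated, though they also show no gain beyond the scatter. The reading for compound 3 is a limit and not a number, so only a floor for the step can be given: the limit of > 25000 nM in this assay, at which 1 of the 3 values shown sits.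

The compounds shown leave open whether other groups at this position, such as a methoxy group, a primary amine or a carboxylic acid, would keep the number as high. They also leave open whether the same swap would give a similar step on the fused ring system of compound 1.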